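The source may hold more compounds than are shown below. What is called first, only, known or untested is meant among the compounds shown, and "the series" means these compounds.

Compound 1 `COc1ccc(-c2cc3c(OC)cc(OC)cc3n(CC(=O)OCc3ccccc3)c2=O)cc1` - 10000 nM
Compound 2 `COc1ccc(-c2cc3c(OC)cc(OC)cc3n(CCC#N)c2=O)cc1` - 10000 nM

Within the data shown here, in a functional assay on A-427 cells (Homo sapiens) for cytotoxicity, read by colorimetric assay and MTT assay (a lower number here means a stronger inhibitor, a higher number a weaker inhibitor), compound 2 gives 10000 nM and stands level with compound 1 on the numbers so far. Compound 3 `CCN(CC)C(=O)CCn1c(=O)c(-c2ccc(OC)cc2)cc2c(OC)cc(OC)cc21` has diethylcarbamoyl in place of cyano on a saturated chain carbon, two bonds along the chain from an aromatic nitrogen. Among the measured compounds shown here, the only measured step on this chain is no change at the digits printed from compound 1 to compound 2 (within the scatter) and it stayed within the scatter. The expected move is therefore no change at the digits printed from compound 2 to compound 3 (within the scatter) and no shift beyond the scatter is expected in either direction in this assay for this change. Compound 3 is estimated at 10000 nM (estimated range 4000 nM to 20000 nM).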

Compound 3, half-maximal inhibitory concentration: 10000 nM
The estimate for compound 3 equals the measured number at the digits printed; the measured number falls inside the stated range.
By their numbers in this assay, from the lowest: compounds 1, 2 and 3 (each within the scatter of the next).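

In this assay, putting diethylcarbamoyl in place of cyano gives no change at the digits printed from compound 2 to compound 3 (within the scatter), and putting (diethylcarbamoyl)methyl in place of benzyloxycarbonyl gives no change at the digits printed from compound 1 to compound 3 (within the scatter). An amide at the end of this chain, a third kind of end group after the ester and the nitrile, therefore reads the same as both within the scatter. Nothing among the data shown accounts for this sameness. From the compounds shown here alone, it remains open whether an amine or a carboxylic acid at the chain end, or a longer chain, would separate from these three compounds.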